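Series notes: methyl on the aromatic ring, compound 4

The compounds below may be only part of what the source reports. "The series", "measured", "known", "first", "only" and "open" are said of these compounds alone.

Measured so far in a functional assay on the whole organism for inhibition, with Mus musculus as the target, in the maximal electroshock model, at a dose of 30 mg/kg by the oral route; on this read-out higher numbers stand for a stronger effect at the one dose given and lower numbers for a weaker effect:
compound 1, `CN1C(=O)NC2(CC2(C)C)C1=O`, gives 90%
compound 2, `CCCCN1C(=O)NC2(CC2(C)C)C1=O`, gives 90%
compound 3, `CC1(C)CC12NC(=O)N(c1ccccc1)C2=O`, gives 80%

Compound 3 has the lowest of the three numbers, but its gaps to compound 1 and to compound 2 both lie within the scatter, so no order among the three is claimed. Compound 4, `Cc1ccc(N2C(=O)NC3(CC3(C)C)C2=O)cc1`, differs from compound 3 by methyl in place of hydrogen on an aromatic carbon. Going by the values given here, the only measured step, no change at the digits printed from compound 1 to compound 2 (within the scatter), alters a group on the ring nitrogen rather than the aromatic ring, so it bears on this change only loosely; no measured step touches the aromatic ring. Among the compounds with values here, since the one known step was flat and compound 3 already gives 80%, the step of no change at the digits printed from compound 3 to compound 4 (within the scatter) is expected to stay within the scatter. Compound 4 is estimated at 80%, range 60% to 95%.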

Compound 4, a percentage reported as inhibition, in the whole organism at one dose (the size of the read-out at that dose, not a potency): 50%
Compound 4: middle estimate off by 30 percentage points, on the high side; the whole stated range lies above it.
By their numbers in this assay, from the lowest: compound 4; then compounds 3, 1 and 2 (each within the scatter of the next).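

In this assay methyl in place of hydrogen on an aromatic carbon, para to a large group, gives a number 30 percentage points lower from compound 3 to compound 4 (beyond the scatter) and is the only step shown that lies beyond the scatter. The aromatic ring is therefore sensitive to a single methyl, whereas propyl on the saturated chain gave no change at the digits printed from compound 1 to compound 2 (within the scatter) as the other step shown. No measured evidence bears on the reason for this drop.

Going by these compounds, whether ethyl, methoxy or chlorine at this place would give a similar drop remains open. The compounds shown also leave open how methyl would behave elsewhere on the aromatic ring.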